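Methyl in Place of Hydroxyl on the Amide Tail

The compounds below may be only part of what the source reports. "The series", "measured", "known", "first", "only" and "open" are said of these compounds alone.

Measured so far:
compound 1, `O=C(NCCO)c1cccc(-c2cccc3oc(Cc4cccc(C(F)(F)F)c4)cc23)c1`, in a functional assay on CHO cells for agonist activity at G-protein coupled receptor 52 (Homo sapiens), read by AlphaScreen and cAMP accumulation, with a stated time of 30 min (a lower number here means a smaller maximal response, a higher number a larger maximal response), gives 85.7%
compound 2, `O=C(NCCO)c1cccc(-c2cccc3cc(Cc4cccc(C(F)(F)F)c4)sc23)c1`, in this assay gives 79.6%
compound 3, `O=C(NCCO)c1cccc(-c2cccc3nn(Cc4cccc(C(F)(F)F)c4)cc23)c1`, in this assay gives 79.1%

The three compounds share the biaryl amide bearing the trifluoromethylbenzyl group and differ only in the fused heterocycle at the core. Compound 2 sits in the middle of the three numbers in this assay: compound 3 lies a little lower and compound 1 a little higher, but both gaps fall within the usual scatter of this kind of measurement, so the three compounds are not distinguishable here.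

Compound 4, `COCCNC(=O)c1cccc(-c2cccc3cc(Cc4cccc(C(F)(F)F)c4)sc23)c1`, keeps the whole core of compound 2 and changes only the tail of the amide: methyl in place of hydrogen on an oxygen on a saturated carbon. The change adds a single carbon at the far end of the chain and removes the hydroxyl's hydrogen. Among the measured compounds shown here, nothing among the measured compounds speaks to this position, since all three carry the same hydroxyethyl tail, so there is no measured step to lean on.

The maximal response in this assay has been steady across the three cores, and a change this small at the tail is expected to leave it about where it is; the expected step of a number 2.6 percentage points lower from compound 2 to compound 4 (within the scatter) is essentially none beyond the scatter. Compound 4 is therefore estimated at 77%, within a range of 62% to 90%.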

Compound 4, largest response reached (Emax), in percent of the reference or control that the assay uses: 85%
Compound 4: middle estimate off by 8 percentage points, on the low side; the measured number falls inside the stated range.
By their numbers in this assay, from the lowest: compounds 3, 2, 4 and 1 (each within the scatter of the next).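

In this assay, among the compounds shown here, the exchange of 2-hydroxyethyl for 2-methoxyethyl gives a number 5.4 percentage points higher from compound 2 to compound 4 (within the scatter) at a position where all the earlier compounds carried the same tail, so this is the first measured step here. It shows that, on the core of compound 2, the hydrogen on the tail oxygen can be replaced by methyl with no change in maximal response beyond the scatter, and that this response does not depend on keeping a free hydroxyl at the end of the chain. Nothing among the data shown gives a reason for this result.

The compounds shown leave open whether the same exchange would hold on the cores of compound 1 and compound 3, as the 2-methoxyethyl tail appears here only on the core of compound 2. They also leave open how the maximal response would follow a larger change at the end of the tail, such as an amine or a carboxylic acid in place of the hydroxyl, or a longer chain carrying the same oxygen.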